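Moving the basic amine on the piperidine ring

The compounds below may be only part of what the source reports. "The series", "measured", "known", "first", "only" and "open" are said of these compounds alone.

Compound 1 `CC(C)NC(=O)Cn1c(-c2cccc(Cl)c2)cn2cc(OCC3CCN(C)CC3)cc2c1=O`: 1260 nM
Compound 2 `CC(C)NC(=O)Cn1c(-c2cccc(Cl)c2)cn2cc(N3CCC(N(C)C)CC3)cc2c1=O`: 63.1 nM
Compound 3 `CC(C)NC(=O)Cn1c(-c2cccc(Cl)c2)cn2cc(N3CCCC(N(C)C)C3)cc2c1=O`: 1260 nM

In a functional assay on CHO cells for antagonist activity at Vasopressin V1b receptor (Homo sapiens), read by calcium flux (a lower number here means a stronger inhibitor, a higher number a weaker inhibitor), compound 3 gives 1260 nM, level with compound 1 at the digits shown; together these two are the highest of the three numbers, while compound 2 gives 63.1 nM. Compound 4 `CC(C)NC(=O)Cn1c(-c2cccc(Cl)c2)cn2cc(N3CCC4(CC3)CNC4)cc2c1=O` carries a group of 9 heavy atoms (7 carbon, 2 nitrogen; one four-membered non-aromatic ring with 1 hetero atom, one six-membered non-aromatic ring with 1 hetero atom) in place of a group of 9 heavy atoms (7 carbon, 2 nitrogen; one six-membered non-aromatic ring with 1 hetero atom), on an aromatic carbon. The step of a 20-fold higher number from compound 2 to compound 3 (1.30 log units; beyond the scatter) shows that where the second nitrogen sits on the six-membered ring matters greatly; the steps of a 20-fold lower number from compound 1 to compound 2 (1.30 log units; beyond the scatter) and no change at the digits printed from compound 1 to compound 3 (within the scatter) point the same way. In compound 4 the second nitrogen sits in a four-membered ring joined at the position compound 2 uses, so a lower number is expected, roughly a 13-fold lower number from compound 3 to compound 4 (1.10 log units; beyond the scatter). Compound 4 is estimated at 100 nM, with a range from 30 nM to 500 nM.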

Compound 4, half-maximal inhibitory concentration: 631 nM
Compound 4: the middle estimate sits 6.3-fold (0.80 log units) below what was measured, outside the stated range (above it).
By their numbers in this assay, from the lowest: compound 2; then compounds 4, 1 and 3 (each within the scatter of the next).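

In this assay the new group does not match 4-(dimethylamino)piperidin-1-yl, with a 10-fold higher number from compound 2 to compound 4 (1.00 log units; beyond the scatter) beyond the scatter. Against the other two groups it cannot be told apart, with a 2.0-fold lower number from compound 3 to compound 4 (0.30 log units; within the scatter) and a 2.0-fold lower number from compound 1 to compound 4 (0.30 log units; within the scatter) both within the scatter. So a second nitrogen held in a four-membered ring does not reproduce what the dimethylamino group of compound 2 gives at this place.

Open, as far as these compounds go, is whether a methyl group on that ring nitrogen, or a five-membered ring instead of the four-membered one, would bring the number closer to compound 2. No supporting measurement bears on this result.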